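This account rests on a few compounds, and the source may have more. Where it says the series, first, only, none or still open, it means among the compounds named here.

Measured compounds:
Compound 1, `COc1cc(Nc2nc(Cl)cc3c(C(C)C)n[nH]c23)cc(OC)c1OC`: 2.82 nM
Compound 2, `COc1cc(Nc2nc(C#N)cc3c(C(C)C)n[nH]c23)cc(OC)c1OC`: 3.8 nM
Compound 3, `COc1cc(Nc2nc(Cl)cc3c(-c4ccccc4)n[nH]c23)cc(OC)c1OC`: 12.3 nM

In a functional assay on Flp-In-CHO cells for antagonist activity at adenosine receptor A3 (Homo sapiens), read by cAMP accumulation, with a stated time of 30 min (a lower number here means a stronger inhibitor, a higher number a weaker inhibitor), compound 3 gives the highest of the three numbers. Going by the values given here, the gap to compound 2 is beyond the scatter, and so is the one to compound 1, so compound 3 is the weakest inhibitor among the three measured; its step from compound 1 was a 4.4-fold higher number from compound 1 to compound 3 (0.64 log units; beyond the scatter), the phenyl replacing the isopropyl on the shared core.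

Compound 4, `COc1cc(Nc2nc(CN)cc3c(-c4ccccc4)n[nH]c23)cc(OC)c1OC`, keeps the phenyl of compound 3 and alters only the chloro: aminomethyl in place of chloro on an aromatic carbon. Among the compounds with values here, the one measured step at this position is a 1.3-fold higher number from compound 1 to compound 2 (0.13 log units; within the scatter), a swap of chloro for cyano on the isopropyl core that left the number essentially unchanged. Within the data shown here, an aminomethyl is a different kind of replacement, carrying a hydrogen-bond donor and acceptor, and no measured pair shows such a group, so the evidence for the step in this assay is thin. The account therefore expects no more than a modest move, with a slightly weaker inhibitor somewhat more likely than a stronger one. Compound 4 is expected to give about 20 nM, within a range of 6 nM to 70 nM. This estimate means a 1.6-fold higher number from compound 3 to compound 4 (0.21 log units; within the scatter).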

Compound 4, half-maximal inhibitory concentration: 4.9 nM
Compound 4: middle estimate off by 4.1-fold (0.61 log units), on the high side; measured number outside the range, below it.
By their numbers in this assay, from the lowest: compounds 1, 2 and 4 (each within the scatter of the next); then compound 3.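

The step of a 2.5-fold lower number from compound 3 to compound 4 (0.40 log units; beyond the scatter) in this assay shows that the aromatic carbon next to the ring nitrogen can respond to a change of group. The one earlier step at this carbon, a 1.3-fold higher number from compound 1 to compound 2 (0.13 log units; within the scatter), had stayed within the scatter and so had shown no such response. With the phenyl kept in place, the new step also shows that chloro can give way to aminomethyl, which brings a hydrogen-bond donor and acceptor, and the compound remains a low-nanomolar inhibitor with a lower number than before. Nothing in the data shown explains why the number moves in this direction.

The compounds shown leave open which part of the aminomethyl matters, as a plain methyl, a hydroxymethyl, an amine set directly on the ring or a longer aminoethyl chain would be needed to separate the carbon from the nitrogen and to test the length of the link. They also leave open whether aminomethyl lowers the number in the same way when isopropyl replaces the phenyl on the shared core.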